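Isopropylsulfanyl Analogue Weighed Against Three Measured Relatives

This account rests on a few compounds, and the source may have more. Where it says the series, first, only, none or still open, it means among the compounds named here.

Compound 1, `CCCCCCCCOc1nc(N)nc2c1ncn2/C=C1/CC1(CO)CO`, gives > 20000 nM in an ADME assay on CCRF-HSB-2 cells (Homo sapiens) for cytotoxicity, with a stated time of 7 days (on this read-out lower numbers stand for higher toxicity in this test and higher numbers for lower toxicity in this test), which is a limit of the assay and not a number.
Compound 2, `CCCSc1nc(N)nc2c1ncn2/C=C1/CC1(CO)CO`, gives 98000 nM in this assay.
Compound 3, `CCCCCCOc1nc(N)nc2c1ncn2/C=C1/CC1(CO)CO`, gives > 20000 nM in this assay, again only a limit.

Compound 3 therefore stands at the edge of what this assay reports, and it shares that position with compound 1, since (the limit of > 20000 nM in this assay, at which 2 of the 3 values shown sit). For the measured compounds named here, the only compound of the three with a numerical reading is compound 2, carrying propylsulfanyl on the aromatic carbon.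

The next compound, compound 4, `CC(C)Sc1nc(N)nc2c1ncn2/C=C1/CC1(CO)CO`, differs from compound 3 in one place: isopropylsulfanyl in place of hexyloxy on an aromatic carbon.

Going by the values given here, three measured steps touch the same position, yet none can be read. The step that the limit leaves unreadable from compound 2 to compound 3 is masked by the limit of compound 3, the step that the limit leaves unreadable from compound 1 to compound 2 by the limit of compound 1, and the step that the two limits leave unreadable from compound 1 to compound 3 by both limits. Nothing in these numbers says whether a sulfanyl group in place of an alkoxy group moves the read-out, or by how much.

What remains is that compound 2, the nearest relative in kind, returned a number rather than a limit. Compound 4 is thus expected to sit near that number, at an estimated 90000 nM, with a range from 30000 nM to 300000 nM. Relative to compound 3, this estimate implies an expected step that the limit leaves unreadable from compound 3 to compound 4, which the limit makes uncertain.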

Compound 4, half-maximal cytotoxic concentration: 94000 nM
Compound 4: middle estimate off by 1.0-fold (0.02 log units), on the low side; the measured number falls inside the stated range.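

Isopropyl in place of propyl on a sulfur gives a 1.0-fold lower number from compound 2 to compound 4 (0.02 log units; within the scatter) in this assay, so at this aromatic carbon the two sulfanyl groups cannot be told apart. For the compounds shown here, this is the first step at the position that can be read, and it speaks only to the shape of the chain on sulfur, not to the exchange of an alkoxy group for a sulfanyl group. Compound 1 and compound 3 both stand at a limit of the assay and not at a number, so the steps from them to compound 4 cannot be read: the limit of > 20000 nM in this assay, at which 2 of the 4 values shown sit.

On these data alone, whether a propyloxy group, the oxygen counterpart of propylsulfanyl, would read alongside compound 2 and compound 4 stays open, as does any difference between the hexyloxy and octyloxy chains. Also open, as far as these compounds go, is how a longer sulfanyl chain such as hexylsulfanyl, or an amine on the same aromatic carbon, would read in this assay.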